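Aryl swap on the ring nitrogen: toward compound 3

This account rests on a few compounds, and the source may have more. Where it says the series, first, only, none or still open, it means among the compounds named here.

Measured so far in a functional assay on A549 cells (Homo sapiens) for inhibition, read by MTT assay, with a stated time of 72 h (a lower number here means a stronger inhibitor, a higher number a weaker inhibitor), are these:
compound 1 `Cc1cc2occ(-c3nc(-c4ccccc4)c(-c4ccccc4)n3-c3ccc(Cl)c(Cl)c3)c(=O)c2cc1Cl` gives 6250 nM
compound 2 `Cc1cc2occ(-c3nc(-c4ccccc4)c(-c4ccccc4)n3-c3cccc([N+](=O)[O-])c3)c(=O)c2cc1Cl` gives 6250 nM

Level with compound 1, compound 2 stands at 6250 nM on these numbers. Compound 3 `Cc1ccc(-n2c(-c3coc4cc(C)c(Cl)cc4c3=O)nc(-c3ccccc3)c2-c2ccccc2)cc1` carries 4-methylphenyl in place of 3-nitrophenyl on an aromatic nitrogen. For the measured compounds named here, only one step on that nitrogen has been measured (no change at the digits printed from compound 1 to compound 2 (within the scatter)), so the evidence is thin. No step beyond the scatter is expected in this assay for the new group, and no direction is favoured. The estimated move (no change at the digits printed from compound 2 to compound 3 (within the scatter)) stays small. Compound 3 is expected at 6250 nM within an estimated range of 3000 nM to 12500 nM as a working figure.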

Compound 3, half-maximal inhibitory concentration: 12500 nM
Beside the measured number, compound 3's estimate is 2.0-fold (0.30 log units) below it, within the range that was stated.
By their numbers in this assay, from the lowest: compounds 1, 2 and 3 (each within the scatter of the next).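

With 4-methylphenyl on the aromatic nitrogen, this assay gives a 2.0-fold higher number from compound 2 to compound 3 (0.30 log units; within the scatter) and a 2.0-fold higher number from compound 1 to compound 3 (0.30 log units; within the scatter). An aryl group of carbon only thus stays within the scatter of both 3-nitrophenyl and 3,4-dichlorophenyl at this position, and losing the hydrogen-bond acceptors of 3-nitrophenyl brings no step beyond the scatter. No measurement bears on the reason for this. Open, from the compounds shown here alone, is whether any group on this nitrogen gives a step beyond the scatter, for example a phenyl ring carrying an amine or a carboxylic acid, or a longer alkyl chain in place of the aryl ring.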